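Replacing the Nitrophenyl Group of Compound 1

This account rests on a few compounds, and the source may have more. Where it says the series, first, only, none or still open, it means among the compounds named here.

Compound 1 `Nc1scc(CN2CCN(c3ccc([N+](=O)[O-])cc3)CC2)c1C(=O)c1ccc(Cl)cc1` is the weakest of the three measured compounds. In a functional assay on CHO cells with adenosine receptor A1 (Homo sapiens) as the target, read by cAMP accumulation and immunoassay, with a stated time of 6 min, tested at 10 uM (a higher number here means a weaker effect of the compound at the concentration tested, a lower number a stronger effect), compound 1 gives -17%, the highest of the three numbers, and the two others lie well below it. Compound 2 `Nc1scc(CN2CCN(c3ccc(OC(F)(F)F)cc3)CC2)c1C(=O)c1ccc(Cl)cc1` gives -74%, and compound 3 `Nc1scc(CN2CCN(c3cc(F)ccc3F)CC2)c1C(=O)c1ccc(Cl)cc1` gives -80%. The step of a number 57 percentage points lower from compound 1 to compound 2 (beyond the scatter) and the step of a number 63 percentage points lower from compound 1 to compound 3 (beyond the scatter) are both large, whereas the step of a number 6 percentage points lower from compound 2 to compound 3 (within the scatter) stays within the scatter, so the two replacements of the 4-nitrophenyl group end at much the same level.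

Compound 4 `Nc1scc(CN2CCN(c3ccccc3Cl)CC2)c1C(=O)c1ccc(Cl)cc1` has not yet been measured. It differs from compound 1 in one place: 2-chlorophenyl in place of 4-nitrophenyl on an amine nitrogen in a ring. The two measured steps that bear on this change are those from compound 1 to compound 2 and from compound 1 to compound 3, both large and both downward, since each removes the 4-nitrophenyl group from the ring nitrogen in favour of another aromatic group. On that basis a large downward step is expected for compound 4, a number 48 percentage points lower from compound 1 to compound 4 (beyond the scatter). The estimated value for compound 4 is therefore -65%, with a range from -90% to -30%.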

Compound 4, a percentage reported as activity, at one concentration (the size of the read-out at that concentration, not a potency): -18%
Compound 4: the middle estimate sits 47 percentage points below what was measured; the whole stated range lies below it.
By their numbers in this assay, from the lowest: compounds 3 and 2 (each within the scatter of the next); then compounds 4 and 1 (each within the scatter of the next).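

Taking the 4-nitrophenyl group off the ring nitrogen does not by itself produce the large downward change seen earlier: in this assay, 2-chlorophenyl in its place gives a number 1 percentage points lower from compound 1 to compound 4 (within the scatter). The identity of the aromatic group at this position therefore matters, not merely the loss of the nitro-bearing ring, since swapping in 2-chlorophenyl for the other two groups gives a number 62 percentage points higher from compound 3 to compound 4 (beyond the scatter) and a number 56 percentage points higher from compound 2 to compound 4 (beyond the scatter), even though all four compounds carry one substituted six-membered aromatic ring of carbon at this place. Nothing available here accounts for why 2-chlorophenyl falls with 4-nitrophenyl rather than with 2,5-difluorophenyl and 4-(trifluoromethoxy)phenyl.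

The compounds shown leave open whether this split follows the chlorine atom or the place of the substituent on the aromatic ring, a question that 4-chlorophenyl, 2-fluorophenyl and unsubstituted phenyl on the same ring nitrogen would bear on. They also leave open what a benzyl group or a simple alkyl chain would do at this position, where only directly attached aromatic rings appear here.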